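Moving the Ring Nitrogen Within the Pyridine

The source may hold more compounds than are shown below. What is called first, only, known or untested is meant among the compounds shown, and "the series" means these compounds.

Compound 1 (`NS(=O)(=O)Oc1ccc2c(c1)CN(C(=O)c1ccc(N(Cc3ccccc3)Cc3ccco3)cc1)CC2`) and compound 2 (`CCN(Cc1cccnc1)c1ccc(C(=O)N2CCc3ccc(OS(N)(=O)=O)cc3C2)cc1`) share one core and differ in the two groups carried on the amine nitrogen. In a physicochemical assay for lipophilicity (a higher number here means a more lipophilic compound, a lower number a more polar compound), compound 1 gives 1.93. In this assay compound 2 gives 1.93, level with compound 1 at the digits shown; the two values sit within the usual scatter of such measurements, so no order can be read between them. For the measured compounds named here, no two measured compounds differ in a single place, so no measured single step is available to lean on.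

Compound 3 (`CCN(Cc1ccncc1)c1ccc(C(=O)N2CCc3ccc(OS(N)(=O)=O)cc3C2)cc1`) is not yet measured. It differs from compound 2 by pyridin-4-yl in place of pyridin-3-yl on a saturated chain carbon bound to a nitrogen on an aromatic ring, the same atoms being joined differently, with nothing gained or lost in hydrogen-bond donors or acceptors. In this assay the step is expected to be small and in no direction beyond the scatter, namely a number 0.03 log units lower from compound 2 to compound 3 (within the scatter). Compound 3 is therefore estimated at 1.9, with a likely range from 1.55 to 2.25.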

Compound 3, partition coefficient: 1.93
Beside the measured number, compound 3's estimate is 0.03 log units below it; measured number inside the range.
By their numbers in this assay, from the lowest: compounds 1, 2 and 3 (each within the scatter of the next).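

In this assay, for the compounds shown here, the pair of compound 2 and compound 3 gives the only step so far that isolates a single change, and it reads no change at the digits printed from compound 2 to compound 3 (within the scatter). Compound 1 and compound 2 differ in both groups on the amine nitrogen, so their level values could not speak for either group alone, whereas here pyridin-4-yl in place of pyridin-3-yl, on a saturated chain carbon bound to a nitrogen on an aromatic ring, is the only difference, and it leaves no readable mark on this number. Nothing measured here explains why the two pyridines read alike.

On these data alone, this single step covers only two ways of joining the same atoms at this position, so it remains open whether pyridin-2-yl, or a pyridine ring carrying a carboxylic acid or an amine, would also stay level with compound 2. The ethyl group on the same amine nitrogen has not been tested as a single change either, so a longer chain such as butyl in its place is an open question too.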